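The compounds below may be only part of what the source reports. "The series", "measured", "known", "first", "only" and "open" are said of these compounds alone.

Among the measured compounds shown here, compound 2 `O=S(=O)(NCCCCNCc1ccc(Br)cc1)c1cc(C(F)(F)F)cc(C(F)(F)F)c1` gives 1700 nM in a functional assay on BXPC-3 cells (Homo sapiens) for inhibition, read by MTT assay, with a stated time of 72 h (a lower number here means a stronger inhibitor of growth, a higher number a weaker inhibitor of growth), the second highest of the three numbers so far: compound 1 `O=S(=O)(NCCNCc1ccc(-c2ccccc2)cc1)c1cc(C(F)(F)F)cc(C(F)(F)F)c1` gives 1600 nM, within the scatter of compound 2, while compound 3 `CN(CCCNS(=O)(=O)c1cc(C(F)(F)F)cc(C(F)(F)F)c1)Cc1ccccc1` gives 39000 nM, the step of a 23-fold higher number from compound 2 to compound 3 (1.36 log units; beyond the scatter) being well beyond the scatter. Compound 4 `O=S(=O)(NCCCNCc1ccccc1)c1cc(C(F)(F)F)cc(C(F)(F)F)c1` is not yet measured; it differs from compound 2 by benzylamino in place of ((4-bromobenzyl)amino)methyl on a saturated chain carbon, three bonds along the chain from a sulfonamide nitrogen. For the measured compounds named here, only the step from compound 2 to compound 3 bears on this change, and it shares with it the shortened chain and the loss of bromine, but also carries a methylated amine that compound 4 does not. For compound 4 a weakening is therefore expected, estimated at a 2.9-fold higher number from compound 2 to compound 4 (0.47 log units; beyond the scatter), smaller than the step to compound 3. Compound 4 is expected to give 5000 nM, within 1500 nM to 20000 nM.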

Compound 4, concentration for 50% growth inhibition: 13000 nM
Estimate against measurement, compound 4: 2.6-fold (0.41 log units) below; the range from low to high includes it.
By their numbers in this assay, from the lowest: compounds 1 and 2 (each within the scatter of the next); then compound 4; then compound 3.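

In this assay, among the compounds shown here, hydrogen in place of methyl on the amine nitrogen gives a 3.0-fold lower number from compound 3 to compound 4 (0.48 log units; beyond the scatter), the first reading of that single change. Compound 4 still stands well short of compound 2, with a 7.6-fold higher number from compound 2 to compound 4 (0.88 log units; beyond the scatter), so the bromine and the longer chain together account for a step beyond the scatter even without the methyl. No measurement here explains either step.

From the compounds shown here alone, the split of that step between bromine and chain length stays open. A 4-bromobenzyl amine on the chain of compound 4 would separate the two.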